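Notes on a ring change at compound 2

The compounds below may be only part of what the source reports. "The series", "measured", "known", "first", "only" and "open" are said of these compounds alone.

In a functional assay on A 172 cells (Homo sapiens) for cytotoxicity, read by colorimetric assay and MTT assay (on this read-out higher numbers stand for weaker inhibition and lower numbers for stronger inhibition), compound 1 `COc1cc(OC)c2cc(-c3ccccc3)c(O)nc2c1` gives 10000 nM as its reading. Compound 2 `COc1ccc(-c2cc3c(OC)cc(OC)cc3n(C)/c2=N\Nc2ccccc2)cc1` gives 10000 nM and stands level with compound 1 within the scatter. Compound 3 `COc1ccc(-c2cc3c(OC)cc(OC)cc3n(C)/c2=N\Nc2ccccn2)cc1` has pyridin-2-yl in place of phenyl on an amine nitrogen. Among the measured compounds shown here, no measured step yet sizes this change, so the expectation is loose. The estimated step is modest and toward stronger inhibition (a 1.7-fold lower number from compound 2 to compound 3 (0.22 log units; within the scatter)). For compound 3 the estimate is 6000 nM with 1000 nM to 15000 nM as the expected range.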

Compound 3, half-maximal inhibitory concentration: 10000 nM
Beside the measured number, compound 3's estimate is 1.7-fold (0.22 log units) below it, within the range that was stated.
By their numbers in this assay, from the lowest: compounds 1, 2 and 3 (each within the scatter of the next).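

In this assay, pyridin-2-yl in place of phenyl on an amine nitrogen gives no change at the digits printed from compound 2 to compound 3 (within the scatter), the first step sized at this position. The hydrogen-bond acceptor that enters with pyridin-2-yl leaves the reading of compound 3 level with that of compound 2. Nothing at hand explains this result. Still open, as far as these compounds go, is whether an amine or a carboxylic acid on the pyridin-2-yl ring would separate from compound 3. Also open, from the compounds shown here alone, is whether a longer chain in place of the ring on that amine nitrogen would separate from compound 2.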